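The source may report more compounds than this note shows. Statements on the series, on what has been measured and on what is new or still open speak of the compounds shown alone.

Three compounds sharing one core, and differing in the aryl group on the sulfur, have been tested in a functional assay on HeLa cells (Homo sapiens) for inhibition, read by CCK-8 assay, with a stated time of 72 h, tested at 2 uM; a higher number here means more inhibition of growth at the concentration tested, a lower number less inhibition of growth. In it, compound 1 (`Cc1cc(C)cc(SCc2ccc(/C=C/C(=O)Nc3ccccc3N)cc2)c1`) gives 11.7%, compound 2 (`Nc1ccccc1NC(=O)/C=C/c1ccc(CSc2ccc(C(F)(F)F)cn2)cc1`) gives 6.07% and compound 3 (`Cc1ccc(SCc2ccc(/C=C/C(=O)Nc3ccccc3N)cc2)cc1`) gives 25.5%. Compound 3 therefore stands highest of the three, clear of both others. The next compound, compound 4 (`Nc1ccccc1NC(=O)/C=C/c1ccc(CSc2ccc(F)cc2)cc1`), keeps everything in compound 3 except one group, with fluoro in place of methyl on an aromatic carbon. The 4-methylphenyl thus becomes 4-fluorophenyl.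

For the measured compounds named here, no measured pair makes this exact exchange, so the evidence is indirect. Two steps replace the group on the sulfur and end at compound 3: a number 13.8 percentage points higher from compound 1 to compound 3 (beyond the scatter) and a number 19.4 percentage points higher from compound 2 to compound 3 (beyond the scatter). The third, a number 5.6 percentage points lower from compound 1 to compound 2 (within the scatter), shows that two quite different groups can give readings that the scatter does not separate. Both other groups tested read lower than compound 3, so any change to the 4-methylphenyl has so far meant a loss in this assay, though only two cases support this. Since this change is a single atom on the same ring, a smaller downward move is expected, perhaps within the scatter. The expected step is a number 7.5 percentage points lower from compound 3 to compound 4 (within the scatter). For compound 4 the estimate is 18%, with a range from 7% to 32%.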

Compound 4, percent growth inhibition at one concentration: 7.09%
For compound 4 the middle estimate is 10.9 percentage points above the measured one; low and high end bracket the measured number.
By their numbers in this assay, from the lowest: compounds 2, 4 and 1 (each within the scatter of the next); then compound 3.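

In this assay, fluoro in place of methyl on an aromatic carbon, para to a large group, gives a number 18.4 percentage points lower from compound 3 to compound 4 (beyond the scatter), so this one place on the ring is enough to separate compound 4 from compound 3 by more than the scatter. For the compounds shown here, the other two comparisons, a number 1 percentage points higher from compound 2 to compound 4 (within the scatter) and a number 4.6 percentage points lower from compound 1 to compound 4 (within the scatter), put 4-fluorophenyl level with the 5-(trifluoromethyl)pyridin-2-yl and 3,5-dimethylphenyl groups, leaving the 4-methylphenyl of compound 3 as the only group on the sulfur that stands clear of the others. Nothing measured here bears on the reason for this pattern.

The compounds shown leave open whether the higher reading of compound 3 is specific to methyl or would also appear with ethyl, methoxy, chloro or an amine at the same place on the ring. They also leave open whether the order seen in this assay would hold across a range of concentrations, as every reading here comes from a single one.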